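Swapping the nitrogen substituent: working notes

This account rests on a few compounds, and the source may have more. Where it says the series, first, only, none or still open, it means among the compounds named here.

In a physicochemical assay for solubility, in phosphate buffer, at pH 7.4 (a higher number here means a more soluble compound, a lower number a less soluble compound), compound 1 `Cc1ccc(Nc2nc(N)nc(COc3cccc(N4CCCC4=O)c3)n2)cc1Cl` gives 28000 nM and compound 2 `Cc1cc(OCc2nc(N)nc(NC3(Cc4cccc(Cl)c4)CC3)n2)cc(N2CCCC2=O)c1` gives 23000 nM, two values within the scatter of each other. Compound 3 `Cc1cc(OCc2nc(N)nc(NCCC3CCCCC3(F)F)n2)cc(N2CCCC2=O)c1` differs from compound 2 by 2-(2,2-difluorocyclohexyl)ethyl in place of 1-(3-chlorobenzyl)cyclopropyl on a nitrogen on an aromatic ring. The two measured compounds offer no direct comparison for this change, and neither carries the entering group. From the compounds shown here alone, no step beyond the scatter is expected in this assay, and the direction remains open. The expected step is a 1.1-fold higher number from compound 2 to compound 3 (0.04 log units; within the scatter). For compound 3 the estimated solubility is 25000 nM, with an expected range of 8000 nM to 70000 nM.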

Compound 3, solubility: 55000 nM
Compound 3: the middle estimate sits 2.2-fold (0.34 log units) below what was measured; the range from low to high includes it.
By their numbers in this assay, from the lowest: compounds 2, 1 and 3 (each within the scatter of the next, the first and the last beyond it).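

Going by these compounds alone, on a nitrogen on an aromatic ring, 2-(2,2-difluorocyclohexyl)ethyl in place of 1-(3-chlorobenzyl)cyclopropyl gives a 2.4-fold higher number from compound 2 to compound 3 (0.38 log units; beyond the scatter) in this assay and so provides the first readable step at this position. The step is modest, but it shows that the substituent at this place can move the read-out beyond the scatter. Nothing available bears on what lies behind the step.

Which part of the exchange carries the step remains open: the loss of the chlorine-bearing benzyl part, the cyclopropyl ring or the arrival of the two fluorines. A plain 2-cyclohexylethyl group would test the fluorines alone.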